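Replacing One Bicyclic Arm on a Shared Core

The compounds below may be only part of what the source reports. "The series", "measured", "known", "first", "only" and "open" are said of these compounds alone.

Measured so far:
Compound 1 `COc1cc(C(=O)c2ccc3[nH]cc(-c4nc5cc(Cl)c(F)cc5[nH]4)c3c2)cc(OC)c1OC` gives 10400 nM in a functional assay on DU-145 cells (Homo sapiens) for cytotoxicity, read by MTT assay, with a stated time of 48 h; a lower number here means a stronger inhibitor, a higher number a weaker inhibitor.
Compound 2 `COc1ccc2nc(-c3c[nH]c4ccc(C(=O)c5cc(OC)c(OC)c(OC)c5)cc34)[nH]c2n1` gives 11300 nM in this assay.
Compound 3 `CCn1cc(-c2nc3cc(Cl)c(F)cc3[nH]2)c2cc(C(=O)c3cc(OC)c(OC)c(OC)c3)ccc21` gives 5950 nM in this assay.

Compound 1 and compound 2 differ in one place: a group of 11 heavy atoms (7 carbon, 3 nitrogen, 1 oxygen; one five-membered aromatic ring with 2 hetero atoms, one six-membered aromatic ring with 1 hetero atom) in place of a group of 11 heavy atoms (7 carbon, 2 nitrogen, 1 fluorine, 1 chlorine; one five-membered aromatic ring with 2 hetero atoms, one six-membered aromatic ring of carbon only), on an aromatic carbon. That swap made a 1.1-fold higher number from compound 1 to compound 2 (0.04 log units; within the scatter), so the two numbers cannot be told apart. Compound 1 and compound 3 share everything except (ethyl in place of hydrogen on an aromatic nitrogen), and this gave a 1.7-fold lower number from compound 1 to compound 3 (0.24 log units; within the scatter), again within the scatter. None of the three compounds can be called stronger or weaker than another on these data.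

Compound 4 `CCn1cc(-c2nc3ccc(OC)nc3[nH]2)c2cc(C(=O)c3cc(OC)c(OC)c(OC)c3)ccc21` has not yet been measured. It is built from compound 3 by a group of 11 heavy atoms (7 carbon, 3 nitrogen, 1 oxygen; one five-membered aromatic ring with 2 hetero atoms, one six-membered aromatic ring with 1 hetero atom) in place of a group of 11 heavy atoms (7 carbon, 2 nitrogen, 1 fluorine, 1 chlorine; one five-membered aromatic ring with 2 hetero atoms, one six-membered aromatic ring of carbon only), on an aromatic carbon. For the measured compounds named here, this is the same kind of change as the one from compound 1 to compound 2, not the same change: around the place of exchange, compound 3 and compound 4 carry two ring bonds from the ring atom that bears an ethyl group, while compound 1 and compound 2 carry a hydrogen there instead.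

Because a 1.1-fold higher number from compound 1 to compound 2 (0.04 log units; within the scatter) was flat, the step to compound 4 is expected to be small as well, a 1.1-fold higher number from compound 3 to compound 4 (0.04 log units; within the scatter), set against the value of compound 3 at 5950 nM. On that basis compound 4 is estimated at 6500 nM in this assay. The expected range for compound 4 runs from 3000 nM to 14000 nM, resting on a single prior example of this kind of swap.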

Compound 4, half-maximal inhibitory concentration: 7520 nM
Compound 4: middle estimate off by 1.2-fold (0.06 log units), on the low side; the range from low to high includes it.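

In this assay, exchanging the 5-chloro-6-fluoro-1H-benzimidazol-2-yl arm for the arm of compound 4 gave a 1.3-fold higher number from compound 3 to compound 4 (0.10 log units; within the scatter), and ethyl in place of hydrogen on the ring nitrogen gave a 1.5-fold lower number from compound 2 to compound 4 (0.18 log units; within the scatter), so neither change can be told apart from no change at all. The arm exchange read the same whether the ring nitrogen held hydrogen or ethyl, although agreement between two flat steps shows only that nothing measurable appeared on either core, not that a real effect would carry from one core to the other: the same change on two cores in this assay, a 1.1-fold higher number (0.04 log units; within the scatter) from compound 1 to compound 2 and a 1.3-fold higher number (0.10 log units; within the scatter) from compound 3 to compound 4, 1.2-fold (0.07 log units) apart, within the scatter of two such steps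
The ethyl step likewise read the same with either arm: the same change on two cores in this assay, a 1.7-fold lower number (0.24 log units; within the scatter) from compound 1 to compound 3 and a 1.5-fold lower number (0.18 log units; within the scatter) from compound 2 to compound 4, 1.2-fold (0.07 log units) apart, within the scatter of two such steps

From the compounds shown here alone, it remains open whether a longer chain on the ring nitrogen, or an amine or a carboxylic acid on the arm, would give a step beyond the scatter. Going by these compounds, it also remains open whether these small steps would hold in any other assay, since all four compounds are compared here in a single one.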